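Chain length, not the aryl amide, sets the ceiling

The compounds below may be only part of what the source reports. "The series", "measured", "known", "first", "only" and "open" are said of these compounds alone.

Compound 1 `CCCCCCCCCCCCCCNC(=O)[C@@H](NC(=O)c1cc2ccccc2o1)[C@@H](C)O` is the shared core with a 1-benzofuran-2-yl group on the carbonyl carbon; in a functional assay on SW-620 cells (Homo sapiens) for cytotoxicity, read by MTT assay, with a stated time of 48 h (a lower number here means a stronger inhibitor, a higher number a weaker inhibitor), compound 1 gives 26700 nM. Compound 2 `CCCCCCCCCCCCCCNC(=O)[C@@H](NC(=O)c1nccc2ccccc12)[C@@H](C)O` differs by isoquinolin-1-yl in place of 1-benzofuran-2-yl on a carbonyl carbon, and in this assay compound 2 gives 30400 nM. The step is a 1.1-fold higher number from compound 1 to compound 2 (0.06 log units; within the scatter). Compound 3 `CCCCCCCCCCCCCCCCCCNC(=O)[C@@H](NC(=O)c1cc2ccccc2o1)[C@@H](C)O` differs from compound 1 by butyl in place of hydrogen on a saturated chain carbon, ten or more bonds along the chain from an amide-type nitrogen. In this assay compound 3 is reported only as the limit > 200000 nM. The step of an at least 7.4-fold higher number from compound 1 to compound 3 (0.87 log units; beyond the scatter) is therefore a lower bound. Compound 4 `CCCCCCCCCCCCCCCCCCNC(=O)[C@@H](NC(=O)c1nccc2ccccc12)[C@@H](C)O` is not yet measured and differs from compound 3 by isoquinolin-1-yl in place of 1-benzofuran-2-yl on a carbonyl carbon, the same change that separates compound 1 and compound 2, at the same place. Because that change gave a 1.1-fold higher number from compound 1 to compound 2 (0.06 log units; within the scatter), the step that the limit leaves unreadable from compound 3 to compound 4 is expected to be small. Because compound 3 sits at the limit (the limit of > 200000 nM in this assay, at which 1 of the 3 values shown sits), compound 4 is expected to return a limit as well. The estimate for compound 4 is 300000 nM, expected between 150000 nM and 800000 nM.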

Compound 4, half-maximal inhibitory concentration: 136000 nM
Compound 4: middle estimate off by 2.2-fold (0.34 log units), on the high side, outside the stated range (below it).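

Compound 3 is reported in this assay only as a limit, > 200000 nM. Carried to the longer chain, isoquinolin-1-yl in place of 1-benzofuran-2-yl gives an at least 1.4-fold lower number from compound 3 to compound 4 (0.16 log units; that floor lies within the scatter), which is a floor, so the true size of this change on that core is not shown, and agreement with the shorter-chain pair is neither shown nor excluded: the same change on two cores in this assay, a 1.1-fold higher number (0.06 log units; within the scatter) from compound 1 to compound 2 and an at least 1.4-fold lower number (0.16 log units; that floor lies within the scatter) from compound 3 to compound 4; the limit leaves it open whether they differ

The butyl extension of the chain raises the number on both aryl amides, with a 4.5-fold higher number from compound 2 to compound 4 (0.65 log units; beyond the scatter), but whether the size of that step carries over unchanged is not settled: the same change on two cores in this assay, an at least 7.4-fold higher number (0.87 log units; beyond the scatter) from compound 1 to compound 3 and a 4.5-fold higher number (0.65 log units; beyond the scatter) from compound 2 to compound 4; the limit leaves it open whether they differ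

Still open, on these data alone, is how a shorter chain on the shared core, or an amine or a carboxylic acid in place of the aryl group, would read in this assay.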